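The source may hold more compounds than are shown below. What is called first, only, known or untested is meant among the compounds shown, and "the series" means these compounds.

Working notes on the series. Compound 1 `O=c1cc(-c2ccccc2)oc2cc(OCCCCNc3nc4ccc([N+](=O)[O-])cc4s3)cc(O)c12` and compound 2 `O=c1cc(-c2ccccc2)oc2cc(OCCCCNc3nc4ccc(Br)cc4s3)cc(O)c12` share a core and differ only at the substituted benzothiazole. In a functional assay on SK-OV-3 cells (Homo sapiens) for cytotoxicity, read by sulforhodamine B assay, with a stated time of 48 h (a lower number here means a stronger inhibitor, a higher number a weaker inhibitor), compound 1 gives 41.4 ug/mL, and compound 2 gives 35.1 ug/mL. Going by the values given here, the single step so far, a 1.2-fold lower number from compound 1 to compound 2 (0.07 log units; within the scatter), involves bromo in place of nitro on an aromatic carbon. On these two numbers compound 1 has the highest value, with compound 2 nearest, though the gap stays within the scatter, so no order can be drawn between them.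

Compound 3 `O=c1cc(-c2ccccc2)oc2cc(OCCCCNc3nc4c(F)cc(F)cc4s3)cc(O)c12` is not yet measured. The change from compound 1 is 4,6-difluoro-1,3-benzothiazol-2-yl in place of 6-nitro-1,3-benzothiazol-2-yl on an amine nitrogen. Among the compounds with values here, no measured step covers this exact exchange; the only step available, from compound 1 to compound 2, touched the same benzothiazole at one aromatic carbon and stayed within the scatter. On that basis a step within the scatter is expected in this assay, with no direction claimed, so the step from compound 1 to compound 3 is estimated as a 1.1-fold lower number from compound 1 to compound 3 (0.04 log units; within the scatter). Compound 3 is expected to give about 38 ug/mL, between 18 ug/mL and 80 ug/mL.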

Compound 3, half-maximal inhibitory concentration: 36.8 ug/mL
Compound 3: middle estimate off by 1.0-fold (0.01 log units), on the high side; the range from low to high includes it.
By their numbers in this assay, from the lowest: compounds 2, 3 and 1 (each within the scatter of the next).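

Exchanging 6-nitro-1,3-benzothiazol-2-yl for 4,6-difluoro-1,3-benzothiazol-2-yl on the amine nitrogen gives a 1.1-fold lower number from compound 1 to compound 3 (0.05 log units; within the scatter) in this assay, and exchanging 6-bromo-1,3-benzothiazol-2-yl for the same difluoro group gives a 1.0-fold higher number from compound 2 to compound 3 (0.02 log units; within the scatter). The earlier pair showed only that one substituent could replace another on the benzothiazole without a readable step; this result extends that to a group bearing two fluorine atoms, and to an exchange from 4 hydrogen-bond acceptors in the leaving group to 2 in the entering group, so that the nitro, bromo and difluoro compounds cannot be separated in this assay. Nothing measured bears on why these three values stay within the scatter of one another.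

The compounds shown leave open whether this insensitivity holds for very different groups on the benzothiazole, such as an amine or a carboxylic acid, or whether a readable step would appear with one of these. They also leave open whether a longer chain on the amine nitrogen, or a change elsewhere on the shared core, would move the number beyond the scatter.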